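The source may hold more compounds than are shown below. What is called first, only, known or untested is meant among the compounds shown, and "the series" means these compounds.

Compound 3 `CC1CCN(Cc2ccc3nc(NC(=O)N/N=C/c4c[nH]c5ccccc45)sc3c2)CC1` is the unsubstituted indole of the set, and in a functional assay on NCI-H460 cells (Homo sapiens) for cytotoxicity, read by MTT assay, with a stated time of 72 h (a lower number here means a stronger inhibitor, a higher number a weaker inhibitor), compound 3 gives 4130 nM, the highest number of the three measured. Compound 1 `CC1CCN(Cc2ccc3nc(NC(=O)N/N=C/c4cn(Cc5cccc(Cl)c5)c5ccccc45)sc3c2)CC1` gives 280 nM, and compound 2 `CC1CCN(Cc2ccc3nc(NC(=O)N/N=C/c4cn(Cc5ccc(C(C)(C)C)cc5)c5ccccc45)sc3c2)CC1` gives 3370 nM. Compound 4 `CC1CCN(Cc2ccc3nc(NC(=O)N/N=C/c4cn(Cc5ccc(Cl)cc5)c5ccccc45)sc3c2)CC1` differs from compound 3 by 4-chlorobenzyl in place of hydrogen on an aromatic nitrogen. Among the compounds with values here, two steps bear on this change: a 15-fold higher number from compound 1 to compound 3 (1.17 log units; beyond the scatter), whereas a 1.2-fold higher number from compound 2 to compound 3 (0.09 log units; within the scatter). A chlorine on the benzyl thus went with a large gain, while a tert-butyl went with none; the two benzyl groups themselves differed by a 12-fold higher number from compound 1 to compound 2 (1.08 log units; beyond the scatter). The 4-chlorobenzyl of compound 4 is expected to fall between these outcomes, giving a 4.6-fold lower number from compound 3 to compound 4 (0.66 log units; beyond the scatter). Compound 4 is therefore estimated at 900 nM, within 250 nM to 3500 nM.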

Compound 4, half-maximal inhibitory concentration: 400 nM
For compound 4 the middle estimate is 2.3-fold (0.35 log units) above the measured one; measured number inside the range.
By their numbers in this assay, from the lowest: compounds 1 and 4 (each within the scatter of the next); then compounds 2 and 3 (each within the scatter of the next).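

Compound 4 shows that the gain on this aromatic nitrogen is not confined to the 3-chlorobenzyl of compound 1: 4-chlorobenzyl in place of hydrogen gives (a 10-fold lower number from compound 3 to compound 4 (1.01 log units; beyond the scatter)). The chlorine's ring position makes no difference beyond the scatter (a 1.4-fold higher number from compound 1 to compound 4 (0.15 log units; within the scatter)). With the attachment point held the same, chloro in place of tert-butyl gives (an 8.4-fold lower number from compound 2 to compound 4 (0.93 log units; beyond the scatter)), so the group on the benzyl ring matters here.

On these data alone, whether an amine or a carboxylic acid on that ring, or a longer chain in place of the benzyl, would keep this gain remains open. Nothing available explains these steps.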